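Linker length at the aromatic nitrogen: compound 2 to compound 3

A few compounds are considered here, and "the series" means these few. Any claim that something is new, unique, unknown or untested is made for them only; others in the source may bear on it.

Measured so far:
compound 1 `O=C1c2c[n+]([O-])c3ccccc3c2C(=O)c2c1c1ccccc1n2Cc1cn([C@@H]2C[C@H](O)[C@@H](CO)O2)nn1`: 20 nM
compound 2 `O=C1c2c[n+]([O-])c3ccccc3c2C(=O)c2c1c1ccccc1n2CCCCN1CCCCC1`: 190 nM

In a functional assay on A-375 cells (Homo sapiens) for cytotoxicity, read by MTT assay, with a stated time of 72 h (on this read-out higher numbers stand for weaker inhibition and lower numbers for stronger inhibition), compound 1 gives 20 nM and compound 2 gives 190 nM. Within the data shown here, compound 2 thus stands at the higher of the two numbers, with compound 1 its only neighbour; the gap between them lies beyond the scatter. Among the measured compounds shown here, the two differ in the whole group on the aromatic nitrogen of the shared core, so no single-point step between measured compounds is available.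

Compound 3 `O=C1c2c[n+]([O-])c3ccccc3c2C(=O)c2c1c1ccccc1n2CCN1CCCCC1` keeps the core of compound 2 and differs in one place: piperidin-1-yl in place of 2-(piperidin-1-yl)ethyl on a saturated chain carbon, two bonds along the chain from an aromatic nitrogen. For the measured compounds named here, no measured pair isolates this change, so the size of the step cannot be read from the present numbers. The expected step is small, a 1.3-fold higher number from compound 2 to compound 3 (0.12 log units; within the scatter), a slight rise in number that may well stay within the scatter. Compound 3 is accordingly expected to give about 250 nM in this assay, within 80 nM to 800 nM.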

Compound 3, half-maximal inhibitory concentration: 180 nM
For compound 3 the middle estimate is 1.4-fold (0.14 log units) above the measured one, within the range that was stated.
By their numbers in this assay, from the lowest: compound 1; then compounds 3 and 2 (each within the scatter of the next).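

In this assay, replacing the 4-(piperidin-1-yl)butyl group on the aromatic nitrogen with the 2-(piperidin-1-yl)ethyl group gives a 1.1-fold lower number from compound 2 to compound 3 (0.02 log units; within the scatter). Among these compounds, this is the first step that isolates a single change, and it shows that these two chain lengths cannot be told apart on this read-out when the piperidine ring and the shared core are kept. Nothing on hand offers an explanation for this result.

Still open, going by these compounds, is whether a (piperidin-1-yl)methyl group, or a chain longer than the 4-(piperidin-1-yl)butyl group, would stay level with compound 2 and compound 3. Also open, on these data alone, is whether the same insensitivity to chain length would hold with a different amine, such as morpholine, at the end of the chain.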